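A few compounds are considered here, and "the series" means these few. Any claim that something is new, unique, unknown or untested is made for them only; others in the source may bear on it.

Of the compounds shown here, three sharing one core have been measured so far: compound 1 `CCCCCCCCS(=O)(=O)Nc1cc(-c2ccc(-c3ccccc3)cc2)ccc1C(=O)O`, compound 2 `CCCCCCCCS(=O)(=O)Nc1ccc(-c2ccc(-c3ccccc3)cc2)cc1C(=O)O` and compound 3 `CCCCCCCCS(=O)(=O)Nc1ccc(-c2ccc(OC)cc2)cc1C(=O)O`. In an assay on mitochondria (strain BALB/c) for inhibition of glycerol-3-phosphate acyltransferase 1, mitochondrial (Mus musculus), read by scintillation counting, with a stated time of 10 min (on this read-out higher numbers stand for weaker inhibition and lower numbers for stronger inhibition), compound 1 gives 13500 nM, compound 2 gives 29100 nM and compound 3 gives 19500 nM. Compound 3 thus stands second highest of the three numbers; the value of compound 1 lies nearest to it and that of compound 2 furthest, and both gaps fall within the scatter. Within the data shown here, the only step between measured compounds that differ in one place is a 1.5-fold lower number from compound 2 to compound 3 (0.17 log units; within the scatter), which also stays within the scatter. Compound 4 `CCCCCCCCS(=O)(=O)Nc1ccc(CCc2ccccc2)cc1C(=O)O` has not yet been measured; it differs from compound 3 in that (phenethyl in place of 4-methoxyphenyl on an aromatic carbon). Among the measured compounds shown here, no measured step exchanges an aromatic group for a phenethyl group, so the only guide is the small step between compound 2 and compound 3, which suggests that such exchanges at this position move the number little. Compound 4 is therefore expected to show a 1.0-fold higher number from compound 3 to compound 4 (0.01 log units; within the scatter), no change beyond the scatter. The estimate for compound 4 in this assay is 20000 nM, with a range from 7000 nM to 60000 nM.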

Compound 4, half-maximal inhibitory concentration: 37500 nM
The estimate for compound 4 lay 1.9-fold (0.27 log units) below the measured number; measured number inside the range.
By their numbers in this assay, from the lowest: compounds 1, 3, 2 and 4 (each within the scatter of the next, the first and the last beyond it).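

In this assay, the exchange gives a 1.9-fold higher number from compound 3 to compound 4 (0.28 log units; within the scatter), so this position, meta to a carboxy group and para to a large group, accepts phenethyl in place of 4-methoxyphenyl without a change beyond the scatter. The earlier step concerned only methoxy in place of phenyl on the outer aromatic ring, whereas this one replaces the entire 4-methoxyphenyl group, removing its oxygen and its single hydrogen-bond acceptor while keeping the heavy-atom count and one aromatic ring, and the number again stays within the scatter. Nothing available explains why this exchange leaves the number within the scatter. The compounds shown leave open whether an amine or a carboxylic acid on this aromatic carbon would move the number beyond the scatter. They also leave open whether a longer chain in place of the two-carbon link of phenethyl would do so.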